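The compounds below may be only part of what the source reports. "The series", "measured", "known", "first", "only" and "open" are said of these compounds alone.

Working notes on the series. In a functional assay (aorta) with Rattus norvegicus as the target (on this read-out higher numbers stand for an effect only at larger amounts of compound and lower numbers for an effect already at smaller amounts), compound 1 `C=CCNC1=Nc2ccc(F)cc2S(=O)(=O)N1` gives > 300 uM, which is a limit of the assay and not a number. Among the compounds with values here, compound 2 `O=S1(=O)NC(NCC2CC2)=Nc2ccc(Cl)cc21` gives 41.2 uM, the only actual number so far, so it has no second number to be ranked against.

Compound 3 `C=CCNC1=Nc2ccc(Cl)cc2S(=O)(=O)N1` follows from compound 2 with vinyl in place of cyclopropyl on a saturated chain carbon bound to an amine nitrogen. Within the data shown here, no measured pair differs in one place only, so the size of this step cannot be read from the data. A modest move towards higher numbers in this assay is expected, and it may stay within the usual scatter. The estimate amounts to a 1.5-fold higher number from compound 2 to compound 3 (0.16 log units; within the scatter). For compound 3 the expected value is 60 uM, with an estimated range of 20 uM to 200 uM.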

Compound 3, concentration for half-maximal effect: 28.9 uM
The estimate for compound 3 lay 2.1-fold (0.32 log units) above the measured number; the measured number falls inside the stated range.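

In this assay, vinyl in place of cyclopropyl on a saturated chain carbon bound to an amine nitrogen gives a 1.4-fold lower number from compound 2 to compound 3 (0.15 log units; within the scatter), so with chloro on the aromatic carbon, allylamino and (cyclopropylmethyl)amino cannot be told apart. Within the data shown here, the aromatic substituent is the first place where a change registers: chloro in place of fluoro gives an at least 10-fold lower number from compound 1 to compound 3 (1.01 log units; beyond the scatter), the first step beyond the scatter. Compound 1 stands at a limit of the assay and not at a number, so this step has no exact size: the limit of > 300 uM in this assay, at which 1 of the 3 values shown sits.

As far as these compounds go, whether the lower number seen with chloro extends to bromo or trifluoromethyl on that aromatic carbon remains open. So does whether the side chain stays as silent with fluoro in place, or with a longer chain such as butyl.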